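This account rests on a few compounds, and the source may have more. Where it says the series, first, only, none or still open, it means among the compounds named here.

In a physicochemical assay for lipophilicity, measured as octanol-water partition, at pH 7.4 (a higher number here means a more lipophilic compound, a lower number a more polar compound), compound 1 `Cc1ccc2[nH]c(C(=O)N[C@H]3CN(S(=O)(=O)c4ccccc4)C[C@@H]3C(=O)NCCN(C)C)cc2c1` gives 2.1. This lies within the scatter of compound 3 `Cc1ccc2[nH]c(C(=O)N[C@H]3CN(S(=O)(=O)c4ccccc4)C[C@H]3C(=O)NCCN(C)C)cc2c1`, at 2.3, while compound 2 `Cc1ccc2[nH]c(C(=O)N[C@H]3CN(S(=O)(=O)c4cn(C)nc4C)C[C@@H]3C(=O)NCCN(C)C)cc2c1`, at 1.4, sits lower, beyond the scatter. Compound 4 `Cc1ccc2[nH]c(C(=O)N[C@H]3CN(S(=O)(=O)c4ccccc4)C[C@@H]3C(=O)N[C@@H]3CCCN(C)C3)cc2c1` carries 1-methylpiperidin-3-yl in place of 2-(dimethylamino)ethyl on an amide-type nitrogen.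

Neither measured step alters that substituent. A change of the group on a sulfonyl sulfur gave a number 0.70 log units lower from compound 1 to compound 2 (beyond the scatter). A second change gave a number 0.20 log units higher from compound 1 to compound 3 (within the scatter), and that step comes with the fact that compounds 1 and 3 differ only in the configuration as drawn. These steps offer no direct guide to the size of the new one, so the expectation rests on the structural difference alone: the entering group holds more carbon, with the same number of hydrogen-bond acceptors. A modest rise in this assay is therefore expected, with the estimated step being a number 0.40 log units higher from compound 1 to compound 4 (beyond the scatter). Starting from 2.1 for compound 1, the estimate for compound 4 is 2.5, with an expected range of 2 to 3.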

Compound 4, distribution coefficient: 2.7
Compound 4: middle estimate off by 0.20 log units, on the low side, and the stated range covers the measured number.
By their numbers in this assay, from the lowest: compound 2; then compounds 1 and 3 (each within the scatter of the next); then compound 4.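

On an amide-type nitrogen, 1-methylpiperidin-3-yl in place of 2-(dimethylamino)ethyl gave, in this assay, a number 0.60 log units higher from compound 1 to compound 4 (beyond the scatter). Within the data shown here, this is the first view of this position, and it shows that a change here can move the number upward beyond the scatter, the opposite direction to the change on the sulfonyl sulfur, which gave a number 0.70 log units lower from compound 1 to compound 2 (beyond the scatter). The entering group brings a six-membered ring and more carbon with the same count of hydrogen-bond acceptors, but the facts at hand give no cause for this step.

From the compounds shown here alone, whether the step follows the ring or the added carbon stays open, and a 3-(dimethylamino)propyl chain or a 1-methylpyrrolidin-3-yl group on the same nitrogen would bear on that. The opposite configuration at the stereocentre of the 1-methylpiperidin-3-yl group also remains an open question.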